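The source may hold more compounds than are shown below. What is called first, only, known or untested is meant among the compounds shown, and "the series" means these compounds.

Compound 1 `Cc1nn(-c2ccccc2F)c2c1C(c1ccc(F)cc1)CS(=O)(=O)O2` gives 2.13
Compound 2 `COc1ccc(-c2nn(-c3ccccc3F)c3c2C(c2ccc(Br)c(C)c2)CS(=O)(=O)O3)cc1` gives 2.91

In a physicochemical assay for lipophilicity, using the shake flask method, in phosphate buffer, measured as octanol-water partition, with a stated time of 24 h, at pH 7.4 (a lower number here means a more polar compound, a higher number a more lipophilic compound), compound 2 gives 2.91 as the higher of the two numbers, beyond the scatter from compound 1. Compound 3 `Cc1cc(C2CS(=O)(=O)Oc3c2c(C)nn3-c2ccccc2F)ccc1Br` has methyl in place of 4-methoxyphenyl on an aromatic carbon and is still unmeasured. Among the measured compounds shown here, no measured pair shows this change alone. In this assay compound 1, which also carries methyl at that place, gives 2.13 as the lower number, so a moderate drop beyond the scatter is expected. The expected change is a number 0.41 log units lower from compound 2 to compound 3 (beyond the scatter) in this assay overall. For compound 3 the estimate is 2.5 (2.1 to 2.9).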

Compound 3, partition coefficient: 2.26
The estimate for compound 3 lay 0.24 log units above the measured number, within the range that was stated.
By their numbers in this assay, from the lowest: compounds 1 and 3 (each within the scatter of the next); then compound 2.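

In this assay, among the compounds shown here, methyl in place of 4-methoxyphenyl on an aromatic carbon gives a number 0.65 log units lower from compound 2 to compound 3 (beyond the scatter), the first reading of this change alone. The other step, 4-bromo-3-methylphenyl in place of 4-fluorophenyl on a saturated ring carbon, gives a number 0.13 log units higher from compound 1 to compound 3 (within the scatter), so this swap shows no readable difference. Nothing measured here gives a reason for either step. From the compounds shown here alone, how an amine or a carboxylic acid on that aromatic carbon would read remains open, as does whether the methyl step holds with 4-fluorophenyl on the saturated ring carbon.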